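A few compounds are considered here, and "the series" means these few. Any claim that something is new, unique, unknown or untested is made for them only; others in the source may bear on it.

Compound 2 `COc1ccc(C(=O)/C=C/c2cc(-c3cc(OC)c(OC)c(OC)c3)n[nH]2)cc1OC` gives 620 nM in a functional assay on MDA-MB-231 cells (Homo sapiens) for inhibition, read by MTT assay, with a stated time of 48 h (on this read-out higher numbers stand for weaker inhibition and lower numbers for stronger inhibition), the lowest of the two numbers recorded so far. Compound 1 `COc1cc(-c2cc(/C=C/C(=O)c3ccc(Cl)c(Cl)c3)[nH]n2)cc(OC)c1OC` gives 2100 nM. Compound 3 `COc1cc(-c2cc(/C=C/C(=O)c3ccccc3)[nH]n2)cc(OC)c1OC` differs from compound 2 by phenyl in place of 3,4-dimethoxyphenyl on a carbonyl carbon. Within the data shown here, the only step that bears on the group on the carbonyl carbon is a 3.4-fold lower number from compound 1 to compound 2 (0.53 log units; beyond the scatter), in which 3,4-dimethoxyphenyl was favoured over 3,4-dichlorophenyl. That step does not show what a bare phenyl does, so a modest rise in this assay is expected, a 2.1-fold higher number from compound 2 to compound 3 (0.32 log units; beyond the scatter). Compound 3 is therefore estimated at 1300 nM, with a range from 500 nM to 3500 nM.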

Compound 3, half-maximal inhibitory concentration: 2300 nM
For compound 3 the middle estimate is 1.8-fold (0.25 log units) below the measured one; the range from low to high includes it.
By their numbers in this assay, from the lowest: compound 2; then compounds 1 and 3 (each within the scatter of the next).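

In this assay, phenyl in place of 3,4-dimethoxyphenyl on the carbonyl carbon gives a 3.7-fold higher number from compound 2 to compound 3 (0.57 log units; beyond the scatter), so the lower number of compound 2 is not shared by the bare phenyl. Phenyl in place of 3,4-dichlorophenyl gives a 1.1-fold higher number from compound 1 to compound 3 (0.04 log units; within the scatter), so of these three groups only 3,4-dimethoxyphenyl stands apart. Nothing available explains this difference. The compounds shown leave open whether one methoxy group on the phenyl ring would be enough to give the lower number, and how an amine or a carboxylic acid on that ring would read.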